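Two Chlorines in Place of Two Fluorines

The compounds below may be only part of what the source reports. "The series", "measured", "known", "first", "only" and "open" are said of these compounds alone.

Compound 1 `COc1cc(C2=NN(C(C)=O)C(c3cccc(F)c3)O2)cc(OC)c1OC`: 16.5%
Compound 2 `COc1cc(C(=O)N/N=C/c2ccc(F)c(F)c2)cc(OC)c1OC`: 35.1%
Compound 3 `COc1cc(C2=NN(C(C)=O)C(c3ccc(F)c(F)c3)O2)cc(OC)c1OC`: 35.5%

In a functional assay on PC-3 cells (Homo sapiens) for antiproliferative activity, read by MTT assay, tested at 1 uM (on this read-out lower numbers stand for a weaker effect and higher numbers for a stronger effect at the one concentration tested), compound 3 gives 35.5%, the highest of the three numbers, yet compound 2 gives 35.1%, which lies within the usual scatter of it, so these two cannot be ordered. For the measured compounds named here, compound 1 gives 16.5%, and the step of a number 19 percentage points higher from compound 1 to compound 3 (beyond the scatter) is the only single change measured so far. Compound 4 `COc1cc(C2=NN(C(C)=O)C(c3cc(Cl)cc(Cl)c3)O2)cc(OC)c1OC` carries 3,5-dichlorophenyl in place of 3,4-difluorophenyl on a saturated ring carbon. Going by the values given here, no measured pair exchanges one halogen for another, so that step shows only that adding fluoro raised the number. With nothing closer to lean on, the number for compound 4 is expected to stay near that of compound 3, with a step of a number 2.5 percentage points lower from compound 3 to compound 4 (within the scatter) not beyond the scatter. The estimate for compound 4 is 33%, ranging from 15% to 55%.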

Compound 4, a percentage reported as inhibition, at one concentration (the size of the read-out at that concentration, not a potency): 52.7%
For compound 4 the middle estimate is 19.7 percentage points below the measured one; the measured number falls inside the stated range.
By their numbers in this assay, from the lowest: compound 1; then compounds 2 and 3 (each within the scatter of the next); then compound 4.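

In this assay, the group on the saturated ring carbon still has room for a higher number: 3,5-dichlorophenyl in place of 3,4-difluorophenyl gives a number 17.2 percentage points higher from compound 3 to compound 4 (beyond the scatter) and so goes past the earlier ceiling. Against 3-fluorophenyl the same group gives a number 36.2 percentage points higher from compound 1 to compound 4 (beyond the scatter) and this is the largest step so far. Nothing measured here explains either rise.

This change alters both the halogen and where it sits, so the two cannot be told apart. On these data alone, whether an amine or a carboxylic acid on this phenyl ring would keep the number also stays open.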